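Swapping the ring on a benzamide kinase inhibitor

The source may report more compounds than this note shows. Statements on the series, on what has been measured and on what is new or still open speak of the compounds shown alone.

Measured compounds:
Compound 1, `O=C(Nc1cccc(Cl)c1)c1cc(C(F)(F)F)ccc1OCc1ccc(F)cc1`: 12.6 nM
Compound 2, `O=C(Nc1ccnnc1)c1cc(N2CCCC2)ccc1OCc1ccccc1`: 20 nM
Compound 3, `O=C(Nc1cccnc1)c1cc(C(F)(F)F)ccc1OCc1ccccc1`: 12.6 nM

Of the compounds shown here, three have been tested in an assay on Sf9 cells for inhibition of Leucine-rich repeat serine/threonine-protein kinase 2 (Homo sapiens), read by TR-FRET, with stated times of 30 min and 2 h; on this read-out lower numbers stand for stronger inhibition and higher numbers for weaker inhibition. In this assay compound 1 gives 12.6 nM, compound 3 gives 12.6 nM, and compound 2 gives 20 nM. Compound 2 sits at the top of these three numbers, but its gap to compound 1 and its gap to compound 3 both lie within the usual scatter of repeated measurements, so the three compounds cannot be told apart on the data shown.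

Compound 4, `N#CC1CCN(c2ccc(OCc3ccccc3)c(C(=O)Nc3ccnnc3)c2)CC1`, has not been measured. It differs from compound 2 in one place: 4-cyanopiperidin-1-yl in place of pyrrolidin-1-yl on an aromatic carbon. Among the compounds with values here, no pair of measured compounds shows this change, so no measured step tells how large its effect is. The three measured numbers all fall close together despite several differences among their structures, and nothing here points to a change in either direction beyond the scatter.

Compound 4 is therefore expected to give about 20 nM in this assay, with a likely range from 6 nM to 70 nM. The step from compound 2 to compound 4 that this estimate means is no change at the digits printed from compound 2 to compound 4 (within the scatter), an expectation only, to be checked against the measurement.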

Compound 4, half-maximal inhibitory concentration: 10 nM
Compound 4: middle estimate off by 2.0-fold (0.30 log units), on the high side; the range from low to high includes it.
By their numbers in this assay, from the lowest: compounds 4, 1, 3 and 2 (each within the scatter of the next).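

In this assay, within the data shown here, putting 4-cyanopiperidin-1-yl in place of pyrrolidin-1-yl gives a 2.0-fold lower number from compound 2 to compound 4 (0.30 log units; within the scatter), the first step in this set between two compounds that differ in only one place. The earlier compounds shown here differed in several places at once, so they could not show what this position alone does; this pair shows that on this aromatic carbon, para to a benzyloxy group and meta to a (pyridazin-4-yl)carbamoyl group, a six-membered ring bearing a nitrile can replace a five-membered ring with no change that can be told from the scatter. No measurement shown here explains why the two groups read alike.

The compounds shown leave open which part of the new group matters, since a plain piperidin-1-yl group would separate the ring from its nitrile, and a morpholin-4-yl group or a carboxylic acid on the same carbon would test how far this position can be varied. On these data alone, it also remains open whether the same swap would read alike on the core of compound 3, where a trifluoromethyl group occupies this position.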